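This account rests on a few compounds, and the source may have more. Where it says the series, first, only, none or still open, it means among the compounds named here.

Measured so far in a functional assay on A549 cells (Homo sapiens) for inhibition, read by sulforhodamine B assay, with a stated time of 48 h; a lower number here means a stronger inhibitor of growth, a higher number a weaker inhibitor of growth:

- compound 1, `COc1ccc(-c2cc(/C=C/C(=O)c3ccc(N)cc3)[nH]n2)cc1`, gives 2550 nM
- compound 2, `COc1cc(-c2cc(/C=C/C(=O)c3ccc(N)cc3)[nH]n2)cc(OC)c1OC`, gives 2080 nM

Compound 2 has the lowest number of the two, and its nearest neighbour is compound 1; the gap between them is within the scatter of this assay, so the two compounds cannot be told apart on these numbers. Both share the same core, and they differ only in how many methoxy groups sit on the aromatic ring at one end.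

Compound 3, `COc1ccc(-c2cc(/C=C/C(=O)c3ccc(N)cc3)[nH]n2)cc1OC`, has not yet been measured in this assay. It is reached from compound 2 by a single change: hydrogen in place of methoxy on an aromatic carbon. Going by the values given here, no step between two measured compounds matches this change, so there is nothing to read it off from directly. What the two measured compounds show is that going from one methoxy group to three leaves the number essentially where it was. On that basis the step is expected to be small, with no clear direction and no more than the scatter, and the expected step is a 1.1-fold higher number from compound 2 to compound 3 (0.04 log units; within the scatter). Compound 3 is therefore estimated at 2300 nM, within a range from 1000 nM to 5500 nM.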

Compound 3, concentration for 50% growth inhibition: 2750 nM
Compound 3: middle estimate off by 1.2-fold (0.08 log units), on the low side, and the stated range covers the measured number.
By their numbers in this assay, from the lowest: compounds 2, 1 and 3 (each within the scatter of the next).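

The new compound fills the gap between the two earlier ones, which differed by two methoxy groups at once and so could not show what a single methoxy group does. In this assay, going by these compounds alone, hydrogen in place of methoxy on this aromatic carbon, ortho to a methoxy group and meta to a large group, gives a step that cannot be told apart from no step at all (a 1.3-fold higher number from compound 2 to compound 3 (0.12 log units; within the scatter)), and methoxy in place of hydrogen on an aromatic carbon likewise gives a step within the noise (a 1.1-fold higher number from compound 1 to compound 3 (0.03 log units; within the scatter)). One, two and three methoxy groups on this ring therefore give numbers that cannot be separated, and nothing measured here offers an explanation for that.

Going by these compounds, what remains open is whether a group other than methoxy at this position, such as a hydroxyl group, a chlorine atom, an amine or a carboxylic acid, would move the number beyond the scatter. The compounds shown also leave open what happens when this ring carries no methoxy group at all, since every compound here keeps at least one.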